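Halogen swap at the phenol ring across two scaffolds

A few compounds are considered here, and "the series" means these few. Any claim that something is new, unique, unknown or untested is made for them only; others in the source may bear on it.

Measured compounds:
compound 1, `COc1cc(CNC(=S)NCC(COC(=O)C(C)(C)C)Cc2ccc(C)c(C)c2)cc(Cl)c1O`, 30.9 nM
compound 2, `COc1cc(CNC(=S)NCC(COC(=O)C(C)(C)C)Cc2ccc(C)c(C)c2)cc(Br)c1O`, 33.1 nM
compound 3, `COc1cc(CNC(=S)NC(CCc2ccc(C)c(C)c2)COC(=O)C(C)(C)C)cc(Cl)c1O`, 86 nM

In an assay on CHO cells for displacement of a labelled ligand from transient receptor potential cation channel subfamily V member 1 (Rattus norvegicus) (on this read-out lower numbers stand for stronger inhibition and higher numbers for weaker inhibition), compound 1 gives 30.9 nM and compound 2 gives 33.1 nM. The change between them is bromo in place of chloro on an aromatic carbon and the step is a 1.1-fold higher number from compound 1 to compound 2 (0.03 log units; within the scatter), so the two values are not separated. Compound 3 gives 86 nM; how its core differs from that of compound 1 is not broken down here, and compound 3 stands beyond the scatter from both compound 1 and compound 2.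

Compound 4, `COc1cc(CNC(=S)NC(CCc2ccc(C)c(C)c2)COC(=O)C(C)(C)C)cc(Br)c1O`, is not yet measured. Its difference from compound 3 is bromo in place of chloro on an aromatic carbon, the same change seen from compound 1 to compound 2. Because that step was a 1.1-fold higher number from compound 1 to compound 2 (0.03 log units; within the scatter), the step from compound 3 to compound 4 is expected to be small, a 1.0-fold higher number from compound 3 to compound 4 (0.02 log units; within the scatter). Compound 4 is therefore estimated at 90 nM, between 45 nM and 180 nM.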

Compound 4, inhibition constant: 102 nM
Compound 4: middle estimate off by 1.1-fold (0.05 log units), on the low side; the range from low to high includes it.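

In this assay, bromo in place of chloro gives a 1.2-fold higher number from compound 3 to compound 4 (0.07 log units; within the scatter), so the two halogens are not separated on the core of compound 3, as on the core of compound 1. The change carries from one core to the other with no detectable difference in step size: the same change on two cores in this assay, a 1.1-fold higher number (0.03 log units; within the scatter) from compound 1 to compound 2 and a 1.2-fold higher number (0.07 log units; within the scatter) from compound 3 to compound 4, 1.1-fold (0.04 log units) apart, within the scatter of two such steps. Within the data shown here, this rests on two matched pairs and shows only that the swap stays within the scatter on these two cores; it does not show the same for other cores, nor does it exclude a real difference smaller than the scatter.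

The compounds shown carry only chloro or bromo at this position, so the outcome with fluoro, iodo, a nitrile or a plain hydrogen there remains open. Also open, going by these compounds, is whether the same carry-over holds for changes elsewhere, such as a carboxylic acid or an amine in place of the ester.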